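The source may report more compounds than this note shows. Statements on the series, on what has been measured and on what is new or still open speak of the compounds shown alone.

Compound 2 `Clc1ccc(N2C[C@@H]3C[C@H]2CN3)nn1` gives the strongest binding of the three measured compounds in an assay on brain for displacement of a labelled ligand from Neuronal acetylcholine receptor; alpha4/beta2 (Rattus norvegicus) (on this read-out higher numbers stand for weaker inhibition and lower numbers for stronger inhibition), at 6 nM. Compound 1 `C[N+]1(C)C[C@@H]2C[C@H]1CN2c1ccc(-c2ccccc2)nn1` gives 700 nM, and compound 3 `C[N+]1(C)C[C@H]2C[C@@H]1CN2c1ccc(-c2ccccc2)nn1` gives 5500 nM. For the measured compounds named here, the only measured step, a 7.9-fold higher number from compound 1 to compound 3 (0.90 log units; beyond the scatter), rests on the fact that compounds 1 and 3 differ only in the configuration as drawn and concerns configuration alone. Going by the values given here, compound 4 `CN1C[C@@H]2C[C@H]1CN2c1ccc(Cl)nn1` differs from compound 2 by methyl in place of hydrogen on an amine nitrogen in a ring, a change of another kind, so no measured step bears on it directly; compounds 1 and 3 carry two methyl groups and a charge on the amine nitrogen in a ring and differ from compound 2 in more than one place, so their values show only that such compounds sit far weaker. A small weakening, within or just beyond the scatter, is expected, with compound 4 estimated at 15 nM (range 4 nM to 60 nM). The step expected is a 2.5-fold higher number from compound 2 to compound 4 (0.40 log units; beyond the scatter).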

Compound 4, inhibition constant: 139 nM
The estimate for compound 4 lay 9.3-fold (0.97 log units) below the measured number, and the stated range ends below it.
By their numbers in this assay, from the lowest: compound 2; then compound 4; then compound 1; then compound 3.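

Methyl in place of hydrogen on an amine nitrogen in a ring gives a 23-fold higher number from compound 2 to compound 4 (1.36 log units; beyond the scatter) in this assay, so this position responds strongly to one added carbon. For the compounds shown here, compounds 1 and 3 differ from compound 2 in more than one place, and only this pair isolates the methyl, with no net charge. Nothing at hand bears on the cause of this step.

On these data alone, whether an ethyl group or a longer chain on this nitrogen would weaken binding further stays open. So does whether the step keeps its size in the mirror-image configuration.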